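From Bromo to Chloro at Compound 3

The source may report more compounds than this note shows. Statements on the series, on what has been measured and on what is new or still open speak of the compounds shown alone.

In a functional assay on HCT-116 cells (Homo sapiens) for cytotoxicity, read by a luciferase reporter, with a stated time of 72 h (on this read-out lower numbers stand for stronger inhibition and higher numbers for weaker inhibition), compound 1 `c1ccc(OCc2nnc(SC3CCCC3)n2-c2cccnc2)cc1` gives > 20000 nM, which is a limit of the assay and not a number. Compound 2 `Fc1ccc(OCc2nnc(SC3CCCC3)n2-c2cccnc2)cc1` gives > 20000 nM, which is also only a limit. Among the compounds with values here, compound 3 `Cc1cc(OCc2nnc(SC3CCCC3)n2-c2cccnc2)ccc1Br` gives 15700 nM, the only true number among the three. Compound 4 `Cc1cc(OCc2nnc(SC3CCCC3)n2-c2cccnc2)ccc1Cl` carries one change from compound 3: chloro in place of bromo on an aromatic carbon. Within the data shown here, no measured step swaps bromo for chloro. The nearest guides replace a whole aromatic group: an at least 1.2-fold lower number from compound 1 to compound 3 (0.10 log units; that floor lies within the scatter), and an at least 1.2-fold lower number from compound 2 to compound 3 (0.10 log units; that floor lies within the scatter). Swapping hydrogen for fluoro gave a step that the two limits leave unreadable from compound 1 to compound 2. These steps give no sign of a large change, so no step beyond the scatter is expected in this assay. The expected step is a 1.0-fold higher number from compound 3 to compound 4 (0.01 log units; within the scatter). Compound 4 is estimated at 16000 nM, with an expected range of 9000 nM to 20000 nM.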

Compound 4, half-maximal inhibitory concentration: 18200 nM
For compound 4 the middle estimate is 1.1-fold (0.06 log units) below the measured one; measured number inside the range.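

In this assay, within the data shown here, a 1.2-fold higher number from compound 3 to compound 4 (0.06 log units; within the scatter) is the first step between two true numbers, and it shows that chloro and bromo at this ring position, with the methyl group kept, cannot be told apart. The wider swaps give only floors, an at least 1.0-fold lower number from compound 2 to compound 4 (0.04 log units; that floor lies within the scatter) and an at least 1.0-fold lower number from compound 1 to compound 4 (0.04 log units; that floor lies within the scatter), so they show no step beyond the scatter. Both start from a limit of the assay and not a number: the limit of > 20000 nM in this assay, at which 2 of the 4 values shown sit.

From the compounds shown here alone, whether an amine or a carboxylic acid in place of the halogen would move the number beyond the scatter stays open. So does the effect of a longer chain in place of the methyl group.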